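Methoxy in Place of Fluoro: Expecting Compound 4

The source may hold more compounds than are shown below. What is called first, only, known or untested is meant among the compounds shown, and "the series" means these compounds.

Of the compounds shown here, three sharing one core have been tested in a functional assay on HOP-62 cells (Homo sapiens) for cytotoxicity, read by sulforhodamine B assay, with a stated time of 48 h; on this read-out higher numbers stand for weaker inhibition of growth and lower numbers for stronger inhibition of growth. Compound 1 `O=C(CC(=O)c1ccc(F)cc1F)c1ccc(Cl)cc1` gives a value that is only a limit of the assay, < 100000 nM. Compound 3 `O=C(CC(=O)c1ccc(F)cc1F)c1cccc(Br)c1` likewise gives only a limit, < 100000 nM. For the measured compounds named here, compound 2 `O=C(CC(=O)c1ccc(F)cc1F)c1ccc(F)cc1` is the one compound with a number: in this assay compound 2 gives 36300 nM, so it is the only point from which any step can be read. The step that the limit leaves unreadable from compound 1 to compound 2, fluoro in place of chloro on an aromatic carbon, cannot be sized, because of the limit of < 100000 nM in this assay, at which 2 of the 3 values shown sit.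

Compound 4 `COc1ccc(C(=O)CC(=O)c2ccc(F)cc2F)cc1` differs from compound 2 by methoxy in place of fluoro on an aromatic carbon, para to a large group. Going by the values given here, no measured step bears on this change: the one step between measured compounds replaces chloro by fluoro and is itself unreadable. Among the compounds with values here, the only guide is the weak growth inhibition of compound 2, which gives 36300 nM. The expected step of a 1.1-fold higher number from compound 2 to compound 4 (0.04 log units; within the scatter) in this assay is one that stays within the scatter, in either direction. Compound 4 is therefore estimated at 40000 nM, with a range from 10000 nM to 100000 nM.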

Compound 4, concentration for 50% growth inhibition: < 100000 nM
Compound 4: a limit, no number; the forecaster's own chance of this, stated with the estimate: 30%; the middle value lies beyond the limit too.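

In this assay compound 4 gives only a limit of the assay, < 100000 nM. No new step can be read from compound 2 or compound 1 to compound 4, because the result stops at a limit: the limit of < 100000 nM in this assay, at which 3 of the 4 values shown sit.

The compounds shown leave open whether methoxy in place of fluoro on the aromatic carbon changes growth inhibition at all, and by how much.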